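This account rests on a few compounds, and the source may have more. Where it says the series, first, only, none or still open, it means among the compounds named here.

Compound 1 `CCOc1ccc(NC(=O)c2cccc(/C=C3\CC(=O)N(c4ccccc4)C3=O)c2)cc1` — in an ADME assay on NCM460 cells (Homo sapiens) for cytotoxicity, read by MTT assay, with a stated time of 72 h (a higher number here means a weaker inhibitor, a lower number a stronger inhibitor), compound 1 gives > 100000 nM, which is a limit of the assay.
Compound 2 `O=C(Nc1ccc(OC(F)F)cc1)c1cccc(/C=C2\CC(=O)N(c3ccccc3)C2=O)c1` — in this assay compound 2 gives > 100000 nM, likewise a limit.

Compound 2 thus stands at the limit and not at a number; this holds for every value shown here (the limit of > 100000 nM in this assay, at which 2 of the 2 values shown sit). The step that the two limits leave unreadable from compound 1 to compound 2 is left unreadable by the two limits, so nothing about its size can be taken from it.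

Compound 3 `O=C(c1cccc(/C=C2\CC(=O)N(c3ccccc3)C2=O)c1)N1CCCC1` differs from compound 2 by pyrrolidin-1-yl in place of (4-(difluoromethoxy)phenyl)amino on a carbonyl carbon. Going by the values given here, no measured step bears on this change, and the only step available is unreadable, so the expectation rests on the limit at which compound 2 sits. No step beyond the scatter is expected in this assay; the estimated step of a number no higher from compound 2 to compound 3 (the limit leaves the size open) is about none. Compound 3 is expected to give about 100000 nM, between 40000 nM and 300000 nM, most likely again reported as a limit.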

Compound 3, half-maximal inhibitory concentration: > 100000 nM
Compound 3 was reported as a limit; the forecaster's own chance of this, stated with the estimate: 80%; the middle value sits exactly at the limit.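

No new step can be read: the steps from compound 1 and compound 2 to compound 3 in this assay cannot be sized: the limit of > 100000 nM in this assay, at which 3 of the 3 values shown sit.

The compounds shown leave open how far any of these changes would shift the read-out in this assay, as none of them gives a number.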